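Butyl to Nitro on the Aromatic Carbon: Compound 4 Expected

The compounds below may be only part of what the source reports. "The series", "measured", "known", "first", "only" and "open" are said of these compounds alone.

Three amides share one core and differ only in the group on an aromatic carbon of a six-membered aromatic ring of carbon only. In a functional assay on B16 cells (Mus musculus) for inhibition (on this read-out lower numbers stand for stronger inhibition and higher numbers for weaker inhibition), compound 1 `O=C(/C=C/c1ccc(O)c(O)c1)Nc1ccc(C(F)(F)F)cc1` gives 1400 nM, compound 2 `CC(C)c1ccc(NC(=O)/C=C/c2ccc(O)c(O)c2)cc1` gives 3400 nM, and compound 3 `CCCCc1ccc(NC(=O)/C=C/c2ccc(O)c(O)c2)cc1` gives 1200 nM. Compound 3 has the lowest number of the three, though a 1.2-fold lower number from compound 1 to compound 3 (0.07 log units; within the scatter) lies within the scatter, while a 2.8-fold lower number from compound 2 to compound 3 (0.45 log units; beyond the scatter) is beyond it. Compound 4 `O=C(/C=C/c1ccc(O)c(O)c1)Nc1ccc([N+](=O)[O-])cc1` carries nitro in place of butyl on an aromatic carbon. Among the measured compounds shown here, no measured step introduces a nitro group; the steps of a 2.4-fold higher number from compound 1 to compound 2 (0.39 log units; beyond the scatter) and a 2.8-fold lower number from compound 2 to compound 3 (0.45 log units; beyond the scatter) show that exchanging this group moves the read-out only modestly. Compound 4 is therefore expected to give a 1.3-fold higher number from compound 3 to compound 4 (0.10 log units; within the scatter), a change within the scatter. The estimate for compound 4 is 1500 nM, from 600 nM to 4000 nM.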

Compound 4, half-maximal inhibitory concentration: 1400 nM
The estimate for compound 4 lay 1.1-fold (0.03 log units) above the measured number; the measured number falls inside the stated range.
By their numbers in this assay, from the lowest: compounds 3, 1 and 4 (each within the scatter of the next); then compound 2.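

Nitro, made of nitrogen and oxygen, takes the place of the all-carbon butyl without moving the read-out beyond the scatter, a 1.2-fold higher number from compound 3 to compound 4 (0.07 log units; within the scatter), and the same holds against trifluoromethyl, with no change at the digits printed from compound 1 to compound 4 (within the scatter). Compound 2 now stands alone, with a 2.4-fold lower number from compound 2 to compound 4 (0.39 log units; beyond the scatter), and its isopropyl is the only group shown that differs beyond the scatter from all the others. No measured evidence accompanies this result. The compounds shown leave open whether an amine, a carboxylic acid or a chain longer than butyl would stay with compounds 1, 3 and 4 or move away as isopropyl does.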